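This account rests on a few compounds, and the source may have more. Where it says the series, first, only, none or still open, it means among the compounds named here.

In an ADME assay on BJ cells (Homo sapiens) for cytotoxicity, with a stated time of 72 h (on this read-out higher numbers stand for an effect only at larger amounts of compound and lower numbers for an effect already at smaller amounts), three compounds have been measured so far, and for each of them the assay reports a limit rather than a number.

Compound 1, `CCc1ccc(-c2nc3c(c(C)nn3-c3ccccc3)c(-c3ccccc3O)c2C#N)cc1`, gives > 20000 nM.
Compound 2, `CCc1ccc(-c2nc3c(c(C)nn3-c3ccccc3)c(-c3ccccc3F)c2C#N)cc1`, gives > 20000 nM.
Compound 3, `CCc1ccc(-c2nc3c(c(C)nn3-c3ccccc3)c(-c3ccccc3)c2C#N)cc1`, gives > 20000 nM.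

Compound 1 therefore stands at the limit of this assay, and nothing finer can be said of where it sits. Compounds 2 and 3 differ from it only in the group on one aromatic carbon, yet none of the steps among them can be sized: a step that the two limits leave unreadable from compound 1 to compound 2, a step that the two limits leave unreadable from compound 1 to compound 3, and a step that the two limits leave unreadable from compound 2 to compound 3. What the three share is the limit of > 20000 nM in this assay, at which 3 of the 3 values shown sit.

The next compound is compound 4, `C#Cc1ccccc1-c1c(C#N)c(-c2ccc(CC)cc2)nc2c1c(C)nn2-c1ccccc1`. Compared with compound 1 the change is ethynyl in place of hydroxy on an aromatic carbon. The measured steps that bear on this change are the three just named, and all of them are unreadable because of the limit of > 20000 nM in this assay, at which 3 of the 3 values shown sit. Nothing in the data points to a direction or size for the step to compound 4 beyond the scatter, and the most plausible outcome is that this assay again reports only its limit.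

Compound 4 is thus expected to give about 20000 nM, somewhere between 10000 nM and 40000 nM, which would mean an expected a number no higher from compound 1 to compound 4 (the limit leaves the size open).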

Compound 4, half-maximal effective concentration: > 20000 nM
Compound 4 ended at the assay's limit; the forecaster's own chance of this, stated with the estimate: 85%; the middle value sits exactly at the limit.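

In this assay compound 4 gives > 20000 nM and this is a limit of the assay, not a number. The steps to it from compound 1, compound 2 and compound 3 therefore cannot be read, because all of them stop at the same place: the limit of > 20000 nM in this assay, at which 4 of the 4 values shown sit. The compounds shown leave open whether any of these changes on the aromatic carbon alters the effect on these cells at all.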